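Replacing the Methylphenyl Arm with a Thiophene Ring

This account rests on a few compounds, and the source may have more. Where it says the series, first, only, none or still open, it means among the compounds named here.

Of the compounds shown here, three built on one shared core have been measured in a functional assay on CHO cells for agonist activity at Alpha-2C adrenergic receptor (Homo sapiens); a lower number here means a smaller maximal response, a higher number a larger maximal response. Compound 1 `CC(Oc1ccccc1-c1cccnc1)C1=NCCN1` carries a pyridin-3-yl group and gives 1. Compound 2 `CC(Oc1ccccc1-c1ccccc1O)C1=NCCN1` carries a 2-hydroxyphenyl group instead, and in this assay compound 2 gives < 0.3, which is a limit of the assay rather than a number. Compound 3 `Cc1cccc(-c2ccccc2OC(C)C2=NCCN2)c1` carries a 3-methylphenyl group and in this assay compound 3 gives 0.6. Of the two plain numbers, compound 3 stands lowest, separated from compound 1 by the step a number 0.40 lower from compound 1 to compound 3 (beyond the scatter); the remaining value is only a limit (the limit of < 0.3 in this assay, at which 1 of the 3 values shown sits). The step a number at least 0.30 higher from compound 2 to compound 3 (beyond the scatter) runs the other way.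

Compound 4 `CC(Oc1ccccc1-c1cccs1)C1=NCCN1` is compound 3 altered at one place: thiophen-2-yl in place of 3-methylphenyl on an aromatic carbon. The entering group, like the pyridin-3-yl of compound 1, is an aromatic ring with one hetero atom and one hydrogen-bond acceptor, whereas the leaving 3-methylphenyl has none. Among the compounds with values here, the steps that bear on this change are a number 0.40 lower from compound 1 to compound 3 (beyond the scatter) and a number at least 0.30 higher from compound 2 to compound 3 (beyond the scatter), both large and both pointing toward the ring with a hetero atom being the more active partner. A modest step upward, beyond the scatter, is therefore expected. Compound 4 is expected to give 0.8, within the range 0.55 to 1. The step this estimate implies, a number 0.20 higher from compound 3 to compound 4 (beyond the scatter), is an expectation only.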

Compound 4, intrinsic activity: the largest response reached, as a fraction of the reference agonist's: 0.8
For compound 4 middle estimate and measured number coincide at the digits printed; the measured number falls inside the stated range.
By their numbers in this assay, from the lowest: compound 3; then compound 4; then compound 1. At a limit, below all of these: compound 2.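

On this aromatic carbon, the five-membered thiophen-2-yl ring gives a response between those of the two six-membered rings in this assay, with a number 0.20 higher from compound 3 to compound 4 (beyond the scatter) and a number 0.20 lower from compound 1 to compound 4 (beyond the scatter). Thiophen-2-yl and pyridin-3-yl each carry one hetero atom and one hydrogen-bond acceptor, yet their responses differ, so these counts alone do not fix the outcome. The widest step, a number at least 0.50 higher from compound 2 to compound 4 (beyond the scatter), gives only a minimum size, for it starts from a limit of the assay: the limit of < 0.3 in this assay, at which 1 of the 4 values shown sits.

The compounds shown leave open whether a furan-2-yl ring, with oxygen in place of sulfur, or a thiophen-3-yl ring would respond like compound 4. Also open, as far as these compounds go, is how a non-aromatic group, such as an amine or a short alkyl chain, would behave on this carbon.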